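Oxazole-carbonyl piperazines: aryl swap on the ring nitrogen

The compounds below may be only part of what the source reports. "The series", "measured", "known", "first", "only" and "open" are said of these compounds alone.

Compound 2 `Cc1nc(-c2ccc(F)cc2)c(C(=O)N2CCN(c3cccc(Cl)c3)CC2)o1` is measured in a functional assay on HL-60 cells (Homo sapiens) for inhibition, read by MTT assay, with a stated time of 72 h (a higher number here means a weaker inhibitor, a lower number a stronger inhibitor), and gives 40.1 nM. Among the two compounds with numbers it carries the higher one, but its nearest neighbour compound 1 `Cc1nc(-c2ccccc2F)c(C(=O)N2CCN(c3cccc(Cl)c3)CC2)o1` gives 39.4 nM, and the step of a 1.0-fold higher number from compound 1 to compound 2 (0.01 log units; within the scatter) lies within the scatter, so the two cannot be ordered. Compound 3 `COc1ccc(-c2nc(C)oc2C(=O)N2CCN(c3cccc(Cl)c3)CC2)cc1O` is reported in this assay only as "not active" (no number reported), with no number.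

Compound 4 `Cc1ccc(C)c(N2CCN(C(=O)c3oc(C)nc3-c3ccc(F)cc3)CC2)c1` differs from compound 2 by 2,5-dimethylphenyl in place of 3-chlorophenyl on an amine nitrogen in a ring. Within the data shown here, no measured step touches this group: the single step with a number, from the 2-fluorophenyl to the 4-fluorophenyl, sits on the aromatic carbon of the shared core and leaves the 3-chlorophenyl untouched, so it does not bear on the present change. Among the measured compounds shown here, both compounds with numbers carry the 3-chlorophenyl; nothing shows how the ring nitrogen tolerates another aryl, and compound 3 shows only that a change elsewhere can remove activity. The expected step of a 1.5-fold higher number from compound 2 to compound 4 (0.18 log units; within the scatter) is therefore set near zero, with a range wide enough to cover a loss. For compound 4 the estimate in this assay is 60 nM, expected between 15 nM and 300 nM.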

Compound 4, half-maximal inhibitory concentration: 358 nM
Compound 4: middle estimate off by 6.0-fold (0.78 log units), on the low side; measured number outside the range, above it.
By their numbers in this assay, from the lowest: compounds 1 and 2 (each within the scatter of the next); then compound 4.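

In this assay, among these compounds, the ring nitrogen is not indifferent to the aryl it carries: 2,5-dimethylphenyl in place of 3-chlorophenyl gives an 8.9-fold higher number from compound 2 to compound 4 (0.95 log units; beyond the scatter), a step beyond the scatter, whereas the earlier compounds with numbers all carried the 3-chlorophenyl and could say nothing about this position. The step is modest and compound 4 still gives a number, so this one swap weakens the compound without removing measurable inhibition, even though the counts for the two groups show the same single aromatic ring of carbon, no hydrogen-bond donors or acceptors and no net charge. Nothing available on the properties of these two groups accounts for the step.

The swap removes the chlorine and brings in two methyl groups in one change, and the compounds shown do not tell which part of it goes with the higher number. A plain phenyl or a 3-methylphenyl on the ring nitrogen would separate the two parts, and a 3-methoxyphenyl would show whether the position accepts an aryl carrying an oxygen.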